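Series notes: ring amine replacing cycloalkylamino on the core

A few compounds are considered here, and "the series" means these few. Any claim that something is new, unique, unknown or untested is made for them only; others in the source may bear on it.

Compound 1 `COc1cc[nH]c1/C=C1\C(=O)Nc2ccc([N+](=O)[O-])c(N[C@H]3CC[C@H](O)C3)c21` stands as the higher of the two numbers measured in a functional assay on MDA-MB-435 cells (Homo sapiens) for antiproliferative activity, read by MTT assay, with a stated time of 5 days (on this read-out higher numbers stand for weaker inhibition and lower numbers for stronger inhibition), where compound 1 gives 1000 nM. Within the data shown here, compound 2 `COc1cc[nH]c1/C=C1\C(=O)Nc2ccc([N+](=O)[O-])c(N3CC[C@H](O)C3)c21` gives 104 nM in this assay; the single measured step, a 9.6-fold lower number from compound 1 to compound 2 (0.98 log units; beyond the scatter), follows the same kind of change as the one now considered, a ring amine entering for (3-hydroxycyclopentyl)amino. Compound 3 `COc1cc[nH]c1/C=C1\C(=O)Nc2ccc([N+](=O)[O-])c(N3CCCC(O)C3)c21` differs from compound 1 by 3-hydroxypiperidin-1-yl in place of (3-hydroxycyclopentyl)amino on an aromatic carbon. Among the measured compounds shown here, the expected step for compound 3 is a 6.7-fold lower number from compound 1 to compound 3 (0.82 log units; beyond the scatter), downward beyond the scatter, because the one comparable step showed a 9.6-fold lower number from compound 1 to compound 2 (0.98 log units; beyond the scatter). Compound 3 is estimated at 150 nM, range 40 nM to 600 nM.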

Compound 3, half-maximal inhibitory concentration: 250 nM
For compound 3 the middle estimate is 1.7-fold (0.22 log units) below the measured one, within the range that was stated.
By their numbers in this assay, from the lowest: compound 2; then compound 3; then compound 1.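

In this assay, a second ring amine also gives a lower number than (3-hydroxycyclopentyl)amino on this aromatic carbon, a 4.0-fold lower number from compound 1 to compound 3 (0.60 log units; beyond the scatter), so the downward step is not confined to compound 2. Ring size among the ring amines also registers here: 3-hydroxypiperidin-1-yl in place of 3-hydroxypyrrolidin-1-yl gives a 2.4-fold higher number from compound 2 to compound 3 (0.38 log units; beyond the scatter). No evidence on the cause of either step is at hand.

As far as these compounds go, what an unsubstituted piperidin-1-yl or a morpholin-4-yl would give at this position stays open. So does the step to an open-chain dimethylamino group.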